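The source may report more compounds than this note shows. Statements on the series, on what has been measured and on what is new or still open speak of the compounds shown alone.

Compound 1 `NS(=O)(=O)CSc1nnc(Br)n1Cc1ccc(Br)c2ccccc12` carries a sulfonamide whose nitrogen bears only hydrogen, and in an assay on HEK293 cells for inhibition of solute carrier family 22 member 12 (Homo sapiens) (a lower number here means a stronger inhibitor, a higher number a weaker inhibitor), compound 1 gives 365000 nM. Compound 2 `O=S(=O)(CSc1nnc(Br)n1Cc1ccc(Br)c2ccccc12)Nc1ccc(Cl)nc1Cl` puts a 2,6-dichloropyridin-3-yl on that nitrogen, and in this assay compound 2 gives 1660 nM. That single change produced a 220-fold lower number from compound 1 to compound 2 (2.34 log units; beyond the scatter), so of the two numbers measured, compound 2 holds the lower one.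

Compound 3 `O=S(=O)(CSc1nnc(Br)n1Cc1ccc(Br)c2ccccc12)Nc1cnccc1I` differs from compound 2 by 4-iodopyridin-3-yl in place of 2,6-dichloropyridin-3-yl on a sulfonamide nitrogen. Among the measured compounds shown here, the only measured step, from compound 1 to compound 2, concerns placing a ring on a bare sulfonamide nitrogen, whereas here one ring is exchanged for another of similar size; no measured pair shows such an exchange. The large gain of that earlier step is therefore not expected to repeat, and the step from compound 2 to compound 3 is estimated as a 1.8-fold higher number from compound 2 to compound 3 (0.26 log units; within the scatter), within the scatter or only slightly beyond it. Compound 3 is expected to give about 3000 nM in this assay, with a range from 800 nM to 12000 nM.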

Compound 3, half-maximal inhibitory concentration: 10600 nM
Compound 3: middle estimate off by 3.5-fold (0.55 log units), on the low side; measured number inside the range.
By their numbers in this assay, from the lowest: compound 2; then compound 3; then compound 1.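

In this assay the choice of ring on the sulfonamide nitrogen matters, not only the presence of a ring: swapping 2,6-dichloropyridin-3-yl for 4-iodopyridin-3-yl gives a 6.4-fold higher number from compound 2 to compound 3 (0.81 log units; beyond the scatter) and so loses part of the earlier gain. Yet the iodinated ring still keeps much of that gain over the bare sulfonamide, with a 34-fold lower number from compound 1 to compound 3 (1.54 log units; beyond the scatter) as the step. No measurement bears on why the two rings differ in this way.

The two rings differ in both the kind and the number of halogens and in where these sit, so these compounds cannot separate those changes. Also open, going by these compounds, is whether a pyridine ring is needed at all, since a plain phenyl ring or an acetyl group on that nitrogen would be a different case.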